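The compounds below may be only part of what the source reports. "The series", "measured", "known", "first", "only" and "open" are said of these compounds alone.

Measured so far in a functional assay on A-375 cells (Homo sapiens) for inhibition, read by CCK-8 assay, with a stated time of 72 h, tested at 8 uM; a higher number here means more inhibition of growth at the concentration tested, a lower number less inhibition of growth:
- compound 1, `Cc1ccc(SCc2ccc(/C=C/C(=O)Nc3ccccc3N)cc2)cc1`: 31.2%
- compound 2, `Cc1cc(C)cc(SCc2ccc(C(=O)Nc3ccccc3N)cc2)c1`: 74.7%
- compound 3, `Nc1ccccc1NC(=O)c1ccc(CSc2ccc(F)cc2)cc1`: 54.3%

Compound 1 stands lowest of the three numbers. Its nearest neighbour is compound 3, whose value lies beyond the scatter above it; compound 2 lies furthest above, also beyond the scatter. Within the data shown here, compounds 2 and 3 share a direct amide on the core, whereas compound 1 carries the propenamide; no step between these two arrangements is available, so the two values are only noted side by side.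

Compound 4 is `Nc1ccccc1NC(=O)/C=C/c1ccc(CSCCc2ccccc2)cc1`. Relative to compound 1 the change is phenethyl in place of 4-methylphenyl on a sulfur. Among the measured compounds shown here, the only measured step on the sulfur substituent is a number 20.4 percentage points lower from compound 2 to compound 3 (beyond the scatter), an aryl-for-aryl exchange. That step says nothing direct about an aryl-to-alkyl exchange, and it sits on the direct amide core rather than the propenamide core of compound 1. The bearing is therefore weak: a step of modest size in either direction, or none beyond the scatter, is plausible in this assay.

Compound 4 is expected to give about 35%, within 15% to 58%, which means an estimated step of a number 3.8 percentage points higher from compound 1 to compound 4 (within the scatter).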

Compound 4, percent growth inhibition at one concentration: 37.4%
For compound 4 the middle estimate is 2.4 percentage points below the measured one, and the stated range covers the measured number.
By their numbers in this assay, from the lowest: compounds 1 and 4 (each within the scatter of the next); then compound 3; then compound 2.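

In this assay, the first step read at this position on the core of compound 1, phenethyl in place of 4-methylphenyl on a sulfur, gives a number 6.2 percentage points higher from compound 1 to compound 4 (within the scatter). The number therefore stays within the scatter when the aryl group on the sulfur gives way to phenethyl, a group that also holds one six-membered aromatic ring of carbon only, so on this core the exchange shows no effect that can be read in this assay. Among these compounds, the only other step at this position, a number 20.4 percentage points lower from compound 2 to compound 3 (beyond the scatter), is an exchange of one aryl group for another on a different core and cannot be set against this one, and no measurement at hand offers an explanation for either step.

Still open, from the compounds shown here alone, is whether a sulfur substituent carrying an amine or a carboxylic acid, or a chain longer than that of phenethyl, would move the number beyond the scatter on the core of compound 1. Also open, going by these compounds, is whether 3,5-dimethylphenyl on that core, or phenethyl on the core of compound 2, would follow the same course as the groups seen so far.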